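The compounds below may be only part of what the source reports. "The series", "measured", "known", "first", "only" and "open" are said of these compounds alone.

Notes on the series. Compound 1 `CC(C)C(c1ccc(-c2ccc3cccc(F)c3c2)[nH]c1=O)N1CCCCC1=O` carries a 2-oxopiperidin-1-yl group on a saturated chain carbon bound to an aromatic carbon and a saturated chain carbon. For the measured compounds named here, in a functional assay on CHO cells for antagonist activity at prostaglandin E2 receptor EP3 subtype (Homo sapiens), read by cAMP accumulation (a higher number here means a weaker inhibitor, a lower number a stronger inhibitor), compound 1 gives 40 nM, the lower of the two numbers so far. Compound 2 `CCn1ncc2c(F)cc(-c3ccc(C(CC)(CC)c4ncn(C)n4)c(=O)[nH]3)cc21`, built on a different core, gives 96 nM in this assay, and the gap between compound 1 and compound 2 lies beyond the usual scatter. Compound 3 `Cc1nc(C(c2ccc(-c3ccc4cccc(F)c4c3)[nH]c2=O)C(C)C)[nH]c1C` has not been measured. The change from compound 1 is 4,5-dimethyl-1H-imidazol-2-yl in place of 2-oxopiperidin-1-yl on a saturated chain carbon bound to an aromatic carbon and a saturated chain carbon. Going by the values given here, no measured pair shows this exchange, so its effect cannot be read from the numbers at hand, and compound 2 differs from compound 1 in too many places to guide it. With the shared core and the branched chain retained, the expected step is a 1.5-fold higher number from compound 1 to compound 3 (0.18 log units; within the scatter), modest, with a small loss about as likely as a gain. For compound 3 the estimated value in this assay is 60 nM, within a range of 15 nM to 250 nM.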

Compound 3, half-maximal inhibitory concentration: 50 nM
Compound 3: middle estimate off by 1.2-fold (0.08 log units), on the high side; the measured number falls inside the stated range.
By their numbers in this assay, from the lowest: compounds 1, 3 and 2 (each within the scatter of the next, the first and the last beyond it).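

On the saturated chain carbon bound to an aromatic carbon and a saturated chain carbon, 4,5-dimethyl-1H-imidazol-2-yl in place of 2-oxopiperidin-1-yl gives a 1.3-fold higher number from compound 1 to compound 3 (0.10 log units; within the scatter) in this assay. This position therefore holds either a six-membered non-aromatic ring with no hydrogen-bond donor or a five-membered aromatic ring that carries one, and the two numbers stay within the scatter of each other. No measurement at hand accounts for this result.

Open, going by these compounds, is whether another group on this carbon, such as a primary amine or a carboxylic acid, stays in the same range, and whether a plain 1H-imidazol-2-yl group matches the dimethyl form. This single pair also cannot tell whether the exchange would behave alike on the core of compound 2.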